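From Compound 3 to Compound 4: Expected Lipophilicity

This account rests on a few compounds, and the source may have more. Where it says the series, first, only, none or still open, it means among the compounds named here.

Measured so far:
- Compound 1 `Cc1cc(C)cc(NC(=O)COc2cc(C)nc3ccc(OCc4ccccc4)cc23)c1`: in a physicochemical assay for lipophilicity, read by HPLC, in phosphate buffer, measured as chromatographic lipophilicity, at pH 7.4 (a higher number here means a more lipophilic compound, a lower number a more polar compound), compound 1 gives 7.03
- Compound 2 `CCCc1cc(OCC(=O)Nc2cc(C)cc(C)c2)c2cc(OC)ccc2n1`: in this assay compound 2 gives 6.44
- Compound 3 `COc1ccc2nc(C)cc(OCC(=O)NCc3cc(C)cc(C)c3)c2c1`: in this assay compound 3 gives 5.25

All three compounds share the same core, a quinoline-like bicyclic ring bearing an ether-linked acetamide arm, and differ only in the substituents around it. Among the three numbers in this assay compound 3 stands lowest: compound 2 lies above it by a margin beyond the scatter, and compound 1 lies higher still, also beyond the scatter. Within the data shown here, none of the three pairs differs in only one place, so no single step between measured compounds can be isolated.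

Compound 4 `COc1ccc2nc(C)cc(OCC(=O)Nc3ccc(Cl)cc3Cl)c2c1` has not yet been measured in this assay. It is built from compound 3 by one change: 2,4-dichlorophenyl in place of 3,5-dimethylbenzyl on an amide-type nitrogen. Both measured compounds that carry an aromatic ring directly on the amide nitrogen, compound 1 at 7.03 and compound 2 at 6.44, sit well above compound 3, which carries the 3,5-dimethylbenzyl group there.

On that basis, the step in this assay from compound 3 to compound 4 is expected to go upward, by an amount beyond the scatter, as a number 0.75 log units higher from compound 3 to compound 4 (beyond the scatter). Compound 4 is therefore expected to give about 6 in this assay, with a likely range from 5.3 to 6.7.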

Compound 4, distribution coefficient: 6.4
Beside the measured number, compound 4's estimate is 0.40 log units below it; measured number inside the range.
By their numbers in this assay, from the lowest: compound 3; then compounds 4 and 2 (each within the scatter of the next); then compound 1.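

Among these compounds, this is the first step that changes one place only, so it shows directly that the group on the amide-type nitrogen matters in this assay: with the rest of compound 3 held fixed, 2,4-dichlorophenyl in place of 3,5-dimethylbenzyl gives a large rise, a number 1.15 log units higher from compound 3 to compound 4 (beyond the scatter). The rise comes although the two groups match in much of what can be counted, as each has one six-membered aromatic ring of carbon only, no hydrogen-bond donors or acceptors and no net charge, and the entering group is the smaller, with 8 heavy atoms against 9. Nothing measured here explains the size of this step.

The swap changes several things at once, removing the carbon that links the ring to the nitrogen and replacing two methyl groups with two chlorines, and the compounds shown cannot divide the step among these changes. As far as these compounds go, a 2,4-dichlorobenzyl group on the same nitrogen would separate them, and how a carboxylic acid or an amine on that ring would move the number remains open.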